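A few compounds are considered here, and "the series" means these few. Any claim that something is new, unique, unknown or untested is made for them only; others in the source may bear on it.

In a functional assay for inhibition, with Homo sapiens as the target (a higher number here means that more compound is needed for the effect, a lower number that less compound is needed), compound 1 `Nc1ccc(C2=NNC(=O)CC2)cc1` gives 46.4 ug/mL. Compound 2 `CC(C)NCC(=O)Nc1ccc(C2=NNC(=O)CC2)cc1` gives about 46.4 ug/mL, which leaves it level with compound 1. Compound 3 `C=CCNCC(=O)Nc1ccc(C2=NNC(=O)CC2)cc1` differs from compound 2 as follows: allyl in place of isopropyl on an amine nitrogen. Among the compounds with values here, no measured step touches this group directly. Within the data shown here, the one step that bears on it, no change at the digits printed from compound 1 to compound 2 (within the scatter), introduced the whole side chain and stayed within the scatter, so no step beyond the scatter is expected in this assay. The expected change is a 1.0-fold lower number from compound 2 to compound 3 (0.00 log units; within the scatter). For compound 3 the estimated value is 46 ug/mL, with an expected range of 22 ug/mL to 95 ug/mL.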

Compound 3, half-maximal effective concentration: about 21.5 ug/mL
Compound 3: middle estimate off by 2.1-fold (0.33 log units), on the high side, outside the stated range (below it).
By their numbers in this assay, from the lowest: compound 3; then compounds 1 and 2 (each within the scatter of the next).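

In this assay, the group on the amine nitrogen does affect the result: allyl in place of isopropyl gives a 2.2-fold lower number from compound 2 to compound 3 (0.33 log units; beyond the scatter). The added side chain, which made no difference with isopropyl, now shows a 2.2-fold lower number from compound 1 to compound 3 (0.33 log units; beyond the scatter), so its effect depends on the group it carries. No measurement here explains this difference. Going by these compounds, it remains open whether the double bond matters or allyl differs from isopropyl in some other way. A straight propyl group on the same nitrogen would separate these, and a longer chain or a cyclopropyl group would show how far the trend extends.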